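The source may report more compounds than this note shows. Statements on the series, on what has been measured and on what is new or still open speak of the compounds shown alone.

The measured compounds in an assay on microsomes from intestine for inhibition of acyl-CoA:cholesterol acyltransferase (Oryctolagus cuniculus) (on this read-out lower numbers stand for stronger inhibition and higher numbers for weaker inhibition), are compound 1 `CCCCCCCC/C=C/CCCCCCCC(=O)Nc1ccccc1CC` with 1200 nM, compound 2 `CCCCCCCC/C=C/CCCCCCCC(=O)Nc1ccccc1C(C)C` with 600 nM, and compound 3 `CCCCCCCC/C=C/CCCCCCC(C)C(=O)Nc1c(OC)cc(OC)cc1OC` with 36 nM.

Compound 1 and compound 2 share a core and differ by methyl in place of hydrogen on a saturated chain carbon bound to an aromatic carbon and a saturated chain carbon. This change gave a 2.0-fold lower number from compound 1 to compound 2 (0.30 log units; within the scatter), so the two values are not told apart by this assay. Compound 3 has the lowest number of the three, and its steps to compound 2 and to compound 1 both lie beyond the scatter. How the core of compound 3 differs from the core of compound 1 is not broken down here; the two differ in more than one place.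

Compound 4 `CCCCCCCC/C=C/CCCCCCC(C)(C)C(=O)Nc1c(OC)cc(OC)cc1OC` has not yet been measured. It differs from compound 3 by methyl in place of hydrogen on a saturated chain carbon bound to a carbonyl carbon and two saturated chain carbons. Going by the values given here, this is the same kind of change as the one from compound 1 to compound 2, but not the same: there the methyl entered on a saturated chain carbon bound to an aromatic carbon and a saturated chain carbon, here it enters on a saturated chain carbon bound to a carbonyl carbon and two saturated chain carbons. Among the compounds with values here, the only measured step of this kind is within the scatter, so little movement is expected. The step from compound 3 to compound 4 in this assay is expected to be a 1.2-fold lower number from compound 3 to compound 4 (0.08 log units; within the scatter), resting on the small step seen for compound 1 to compound 2. Compound 4 is therefore estimated at 30 nM, with a range from 10 nM to 90 nM.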

Compound 4, half-maximal inhibitory concentration: 44 nM
Compound 4: the middle estimate sits 1.5-fold (0.17 log units) below what was measured; low and high end bracket the measured number.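

In this assay the methyl in place of hydrogen on a saturated chain carbon bound to a carbonyl carbon and two saturated chain carbons gave a 1.2-fold higher number from compound 3 to compound 4 (0.09 log units; within the scatter) and so leaves compound 3 and compound 4 not told apart. Set beside the earlier step, the change reads the same on the two cores within what this assay can resolve: the same change on two cores in this assay, a 2.0-fold lower number (0.30 log units; within the scatter) from compound 1 to compound 2 and a 1.2-fold higher number (0.09 log units; within the scatter) from compound 3 to compound 4, 2.4-fold (0.39 log units) apart, within the scatter of two such steps

This shows that, in both measured pairs, adding one methyl to a saturated chain carbon left the number within the scatter, even though the carbon bearing it differs between the pairs. It does not show that the change would stay this small on any other core, and two pairs that differ both in core and in the carbon carrying the methyl cannot separate those two factors.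

The compounds shown leave open whether an ethyl group, a hydroxyl group or a carboxylic acid on the carbon bound to the carbonyl carbon would also leave the number within the scatter. They also leave open what the same methyl would do on the carbon bound to the carbonyl carbon in the core of compound 1.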